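Swapping the Aryl Group on the Amide of Compound 1

The compounds below may be only part of what the source reports. "The series", "measured", "known", "first", "only" and "open" are said of these compounds alone.

Compound 1 `COc1ccc2c(=O)c(/C=C/C(=O)Nc3cccc(Cl)c3)coc2c1` carries a 3-chlorophenyl on its amide nitrogen. In a functional assay (QGY7701 cells, Homo sapiens) for inhibition, read by MTT assay, with a stated time of 48 h (a higher number here means a weaker inhibitor, a lower number a stronger inhibitor), compound 1 gives > 100000 nM, which is a limit of the assay rather than a measured number. Compound 4 `COc1ccc2c(=O)c(/C=C/C(=O)Nc3ccccc3OC)coc2c1` differs from compound 1 in one place (2-methoxyphenyl in place of 3-chlorophenyl on an amide-type nitrogen). Within the data shown here, no measured pair shows this aryl-for-aryl exchange. The closest steps replace the same 3-chlorophenyl with a benzyl-type group: an at least 12-fold lower number from compound 1 to compound 2 (1.09 log units; beyond the scatter), where compound 2 `COc1ccc2c(=O)c(/C=C/C(=O)NCc3ccc(F)cc3)coc2c1` gives 7960 nM, and an at least 6.3-fold lower number from compound 1 to compound 3 (0.80 log units; beyond the scatter), where compound 3 `COc1ccc(CNC(=O)/C=C/c2coc3cc(OC)ccc3c2=O)cc1` gives 15700 nM; between those two, a 2.0-fold higher number from compound 2 to compound 3 (0.29 log units; within the scatter). Because compound 1 sits at the limit (the limit of > 100000 nM in this assay, at which 1 of the 3 values shown sits), the true size of any change is uncertain. Compound 4 is expected to remain a weak inhibitor, with the step of an at least 1.2-fold lower number from compound 1 to compound 4 (0.09 log units; that floor lies within the scatter) estimated as small. The value of compound 4 is estimated at 80000 nM, within a range of 20000 nM to 300000 nM.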

Compound 4, half-maximal inhibitory concentration: 17600 nM
Compound 4: the middle estimate sits 4.5-fold (0.66 log units) above what was measured, outside the stated range (below it).
By their numbers in this assay, from the lowest: compounds 2, 3 and 4 (each within the scatter of the next, the first and the last beyond it). At a limit, above all of these: compound 1.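

Exchanging one aryl group for another on the amide nitrogen gives an at least 5.6-fold lower number from compound 1 to compound 4 (0.75 log units; beyond the scatter), so a benzyl-type group is not needed to bring a compound off the limit. Against the benzyl compounds, the two comparisons differ: a 1.1-fold higher number from compound 3 to compound 4 (0.05 log units; within the scatter), whereas a 2.2-fold higher number from compound 2 to compound 4 (0.34 log units; beyond the scatter). The full size of the first step stays uncertain because compound 1 has only a limit: the limit of > 100000 nM in this assay, at which 1 of the 4 values shown sits.

The compounds shown do not separate the effect of gaining methoxy from that of losing chloro. From the compounds shown here alone, how an aminoethyl or carboxymethyl group on the amide nitrogen would compare also remains open.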